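The source may report more compounds than this note shows. Statements on the series, on what has been measured and on what is new or still open speak of the compounds shown alone.

Measured compounds:
- compound 1 `O=C(O)CCC/C=C\C[C@H]1[C@@H]2CCC(C2)[C@@H]1NS(=O)(=O)c1ccccc1`: 1000 nM; 7400 nM; 600 nM (3 entries)
- compound 2 `COc1ccc(S(=O)(=O)N[C@H]2C3CC[C@H](C3)[C@@H]2C/C=C\CCCC(=O)O)cc1`: 1700 nM
- compound 3 `O=C(O)CCC/C=C\C[C@H]1[C@@H]2CCC(C2)[C@@H]1NS(=O)(=O)CCCc1ccccc1`: 14000 nM

In a functional assay (plasma) for inhibition, with Oryctolagus cuniculus as the target (a higher number here means a weaker inhibitor, a lower number a stronger inhibitor), compound 3 gives the highest number of the two single values, with compound 2 nearest, as the step of an 8.2-fold higher number from compound 2 to compound 3 (0.92 log units; beyond the scatter) shows. Compound 1 has several entries in this assay (the several entries of compound 1 in this assay, 1000 nM; 7400 nM; 600 nM (3 entries)), which gives a sense of how far repeats can spread.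

Compound 4 `O=C(O)CCC/C=C\C[C@H]1[C@@H]2CCC(C2)[C@@H]1NS(=O)(=O)c1ccc(O)cc1` differs from compound 3 only at the sulfonyl sulfur: 4-hydroxyphenyl in place of 3-phenylpropyl on a sulfonyl sulfur

Within the data shown here, the one measured step that bears on this change is an 8.2-fold higher number from compound 2 to compound 3 (0.92 log units; beyond the scatter), where an aromatic ring gave way to a 3-phenylpropyl chain and the number rose. Compound 4 moves back toward an aromatic ring, so the expected step of a 9.3-fold lower number from compound 3 to compound 4 (0.97 log units; beyond the scatter) is a fall, estimated near the size of that step. Compound 4 is therefore estimated at 1500 nM, between 400 nM and 6000 nM.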

Compound 4, half-maximal inhibitory concentration: 500 nM
For compound 4 the middle estimate is 3.0-fold (0.48 log units) above the measured one, within the range that was stated.
By their numbers in this assay, from the lowest: compound 4; then compound 2; then compound 3.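

At the sulfonyl sulfur in this assay, 4-hydroxyphenyl in place of 3-phenylpropyl gives a 28-fold lower number from compound 3 to compound 4 (1.45 log units; beyond the scatter), a large step. A change as small as hydrogen in place of methyl on the oxygen of the aromatic ring also counts, with a 3.4-fold lower number from compound 2 to compound 4 (0.53 log units; beyond the scatter). Both steps rest on a single entry for compound 4, and repeats of one compound can spread widely: the several entries of compound 1 in this assay, 1000 nM; 7400 nM; 600 nM (3 entries)

The compounds shown leave open whether an amine or a fluorine on that aromatic ring would do as well as the hydroxy group.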